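Ethoxycarbonyl to carboxy in the antiproliferative series

The compounds below may be only part of what the source reports. "The series", "measured", "known", "first", "only" and "open" are said of these compounds alone.

The series is followed in a functional assay on BAEC cells (Bos taurus) for antiproliferative activity, read by cell counting, with a stated time of 4 days; on this read-out higher numbers stand for weaker inhibition and lower numbers for stronger inhibition. Compound 1 `CCOC(=O)C(=O)N(Cc1cc(F)cc(F)c1)c1ccc2c(c1)OC(C)(CO)CN2C` gives 60000 nM there; this is the only plain number shown, so compound 1 stands alone and cannot be ranked against another number. Compound 2 `CCOC(=O)CN(Cc1cccc(F)c1)c1ccc2c(c1)N(C)CC(C)(COc1ccc(C#N)cc1)O2` reaches only > 100000 nM in this assay, which is a limit and not a number. Of the two values shown, one sits at the limit of > 100000 nM in this assay, at which 1 of the 2 values shown sits. Compound 3 `CN1CC(C)(CO)Oc2cc(N(Cc3cc(F)cc(F)c3)C(=O)C(=O)O)ccc21` is not yet measured. It differs from compound 1 in one place, (hydrogen in place of ethyl on an oxygen next to a carbonyl group); ethoxycarbonyl becomes carboxy. No step between two measured compounds exists, so nothing shown tells how large this change should be. In this assay the change is expected to give a 1.5-fold higher number from compound 1 to compound 3 (0.18 log units; within the scatter), small or toward weaker inhibition. Compound 3 is estimated at 90000 nM, with a range from 25000 nM to 300000 nM, and a fair chance that only a limit is reported.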

Compound 3, half-maximal inhibitory concentration: > 100000 nM
Compound 3: only a limit was reported; the forecaster's own chance of this, stated with the estimate: 45%; at least 1.1-fold (0.04 log units) between middle value and limit.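

In this assay compound 3 gives > 100000 nM, which is a limit and not a number. Hydrogen in place of ethyl on an oxygen next to a carbonyl group gives an at least 1.6-fold higher number from compound 1 to compound 3 (0.22 log units; that floor lies within the scatter); this is the first step that can be read in the series, and it has a floor but no known upper size. Ethoxycarbonyl to carboxy at this place therefore shows no stronger inhibition, and the values shown now gather at the top of the range: the limit of > 100000 nM in this assay, at which 2 of the 3 values shown sit.

On these data alone, how far the true value of compound 3 lies past its limit stays open, and with it whether the step goes beyond the scatter. The compounds shown also do not tell whether a primary carboxamide or a longer ester such as butoxycarbonyl at this place would give stronger inhibition.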